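A few compounds are considered here, and "the series" means these few. Any claim that something is new, unique, unknown or untested is made for them only; others in the source may bear on it.

Compound 1 `N#C[Se]c1ccc(NC(=O)Oc2ccc(F)cc2)cc1`: 37600 nM
Compound 2 `CCOC(=O)Nc1ccc([Se]C#N)cc1`: 38000 nM
Compound 3 `N#C[Se]c1ccc(NC(=O)Oc2ccccc2)cc1`: 41700 nM

All three compounds were measured in a functional assay on HT-29 cells (Homo sapiens) for cytotoxicity, read by MTT assay, with a stated time of 72 h; on this read-out lower numbers stand for stronger inhibition of growth and higher numbers for weaker inhibition of growth. The three numbers lie within the usual scatter of one another, so compound 3 cannot be told apart from compound 1 or compound 2 on this read-out. The two steps that lead to compound 3 make this plain: a 1.1-fold higher number from compound 1 to compound 3 (0.04 log units; within the scatter), and a 1.1-fold higher number from compound 2 to compound 3 (0.04 log units; within the scatter). Neither the loss of the fluoro group nor the exchange of ethyl for phenyl on the carbamate oxygen moved the number beyond the scatter.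

The unmeasured compound 4 `N#C[Se]c1ccc(NC(=O)Oc2ccc(Cl)cc2)cc1` differs from compound 3 in one place: chloro in place of hydrogen on an aromatic carbon. Among the measured compounds shown here, the step that bears most directly on this change is the one from compound 1 to compound 3, where a halogen at the same place was swapped for hydrogen and a 1.1-fold higher number from compound 1 to compound 3 (0.04 log units; within the scatter) resulted. For the measured compounds named here, a chloro group at that position has no measured precedent here, so the only guide is that halogen presence or absence at this place has not mattered so far. The step that this estimate means, a 1.0-fold lower number from compound 3 to compound 4 (0.02 log units; within the scatter), is expected to remain within the scatter. Compound 4 is therefore estimated to give 40000 nM in this assay, with a range from 20000 nM to 80000 nM.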

Compound 4, concentration for total growth inhibition: 40300 nM
Beside the measured number, compound 4's estimate is 1.0-fold (0.00 log units) below it; low and high end bracket the measured number.
By their numbers in this assay, from the lowest: compounds 1, 2, 4 and 3 (each within the scatter of the next).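

The chloro group, on an aromatic carbon para to a large group, gave in this assay a 1.0-fold lower number from compound 3 to compound 4 (0.01 log units; within the scatter) and so joins fluoro as a second halogen at this position that leaves the number within the scatter of hydrogen. Among the compounds shown here, the direct exchange of one halogen for the other, which the earlier compounds could not show, gave a 1.1-fold higher number from compound 1 to compound 4 (0.03 log units; within the scatter) and so hydrogen, fluoro and chloro cannot be told apart at this position on this read-out. Nothing available here speaks to what lies behind this flat result.

From the compounds shown here alone, compound 1, compound 3 and compound 4 carry only hydrogen or a halogen at this position, so it remains open whether a methoxy group, an amine or a carboxylic acid there would move the number beyond the scatter. Going by these compounds, it is also open whether a longer chain in place of the ethyl group of compound 2 would leave the number as undisturbed as the phenyl group of compound 3 did.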